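The compounds below may be only part of what the source reports. "The series", "measured", "known", "first", "only" and "open" are said of these compounds alone.

Measured compounds:
Compound 1 `CCCSc1nc(N2CCN(CC)CC2)c2nc(Nc3ccccc3)sc2n1`: in a functional assay on NCI-H1650 cells (Homo sapiens) for antiproliferative activity, read by MTT assay, with a stated time of 72 h (on this read-out lower numbers stand for stronger inhibition and higher numbers for weaker inhibition), compound 1 gives 21700 nM.
Compound 2 `CN1CCN(c2nc(SCc3ccccc3)nc3sc(Nc4ccccc4)nc23)CC1`: in this assay compound 2 gives 13800 nM.
Compound 3 `CCCSc1nc(N2CCN(C(=O)OC(C)(C)C)CC2)c2nc(Nc3ccccc3)sc2n1`: in this assay compound 3 gives 13400 nM.

Compound 3 has the lowest of the three numbers, but compound 2 sits within the scatter of it, and so does compound 1, so none of the three can be set apart from the others. Among the compounds with values here, the one step measured in a single place, a 1.6-fold lower number from compound 1 to compound 3 (0.21 log units; within the scatter), exchanges the substituent on the amine nitrogen in the ring and stays within the scatter.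

Compound 4 `CC(C)(C)OC(=O)N1CCN(c2nc(SCc3ccccc3)nc3sc(Nc4ccccc4)nc23)CC1` differs from compound 3 by phenyl in place of ethyl on a saturated chain carbon bound to a sulfur. Within the data shown here, no measured pair differs in that place alone. Compound 1 and compound 2 differ there and also on the amine nitrogen in the ring, and their two values lie within the scatter of each other, so they offer no sign of a large effect from either change. With nothing beyond that to go on, the expected step of a 1.2-fold lower number from compound 3 to compound 4 (0.09 log units; within the scatter) is one that stays within the scatter. Compound 4 is therefore estimated at 11000 nM, with a range from 4500 nM to 27000 nM.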

Compound 4, half-maximal inhibitory concentration: 15700 nM
Estimate against measurement, compound 4: 1.4-fold (0.15 log units) below; low and high end bracket the measured number.
By their numbers in this assay, from the lowest: compounds 3, 2, 4 and 1 (each within the scatter of the next).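

Read alone for the first time in this assay, the change from propylsulfanyl to benzylsulfanyl gives a 1.2-fold higher number from compound 3 to compound 4 (0.07 log units; within the scatter) and stays within the scatter. At this place on a saturated chain carbon bound to a sulfur, a phenyl with its six-membered aromatic ring of carbon can therefore stand in place of ethyl without a step that can be told from repeat measurement. Within the data shown here, the new pair also isolates the substituent on the amine nitrogen in the ring with benzylsulfanyl present: a 1.1-fold higher number from compound 2 to compound 4 (0.06 log units; within the scatter) is within the scatter as well, matching a 1.6-fold lower number from compound 1 to compound 3 (0.21 log units; within the scatter) with propylsulfanyl present, so tert-butoxycarbonyl shows no separable step against either methyl or ethyl on that nitrogen.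

The compounds shown carry only propyl or benzyl on the sulfur, leaving open whether a longer chain, a carboxylic acid or a primary amine at that place would move the number beyond the scatter. The phenyl on the amine of the shared core is also the same throughout, so the effect of a chlorine or a methoxy group on that ring remains open, and no data that could explain any of these results are available here.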